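Will trifluoromethyl leave compound 4 at the limit too?

This account rests on a few compounds, and the source may have more. Where it says the series, first, only, none or still open, it means among the compounds named here.

Of the compounds shown here, three that share one core have been tested in a functional assay on CWR22R cells (Homo sapiens) for antiproliferative activity, with a stated time of 96 h; a higher number here means a weaker inhibitor, a lower number a stronger inhibitor. Compound 1 `Cc1cc(=O)oc2cc(OCC(=O)c3ccc(C(C)(C)C)cc3)ccc12` carries a tert-butyl group and gives 22300 nM. Compound 2 `Cc1cc(=O)oc2cc(OCC(=O)c3ccc(C#N)cc3)ccc12` carries a cyano group and reads > 100000 nM, which is a limit and not a number. Compound 3 `Cc1cc(=O)oc2cc(OCC(=O)c3ccc(OC(F)(F)F)cc3)ccc12` carries trifluoromethoxy and reads > 100000 nM, again only a limit. Compound 3 therefore stands at the limit of > 100000 nM in this assay, at which 2 of the 3 values shown sit.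

Swapping out tert-butyl gave an at least 4.4-fold higher number from compound 1 to compound 2 (0.65 log units; beyond the scatter) with cyano, and an at least 4.4-fold higher number from compound 1 to compound 3 (0.65 log units; beyond the scatter) with trifluoromethoxy. Between the two limit compounds there is a step that the two limits leave unreadable from compound 2 to compound 3.

Compound 4 `Cc1cc(=O)oc2cc(OCC(=O)c3ccc(C(F)(F)F)cc3)ccc12` has trifluoromethyl in place of trifluoromethoxy on an aromatic carbon. Among the measured compounds shown here, no measured step covers this exchange directly. The closest guide is the change to compound 3, an at least 4.4-fold higher number from compound 1 to compound 3 (0.65 log units; beyond the scatter), since compound 4 also lacks the tert-butyl group. Compound 4 is therefore expected to remain near the limit, and a second limit reading would be no surprise. The expected change in this assay is a number no higher from compound 3 to compound 4 (the limit leaves the size open), with no clear shift beyond the scatter anticipated. For compound 4 the estimate is 100000 nM, with an expected range from 40000 nM to 200000 nM.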

Compound 4, half-maximal inhibitory concentration: > 100000 nM
Compound 4 was reported as a limit (the forecaster's own chance of this, stated with the estimate: 65%); the middle value sits exactly at the limit.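

In this assay, trifluoromethyl now joins cyano and trifluoromethoxy as a third group that, placed on this aromatic carbon para to a large group, fails to keep a readable value once tert-butyl is gone: an at least 4.4-fold higher number from compound 1 to compound 4 (0.65 log units; beyond the scatter). The steps among compound 2, compound 3 and compound 4 cannot be read, as each joins two limits, so no order among these three groups can be given, and taking the oxygen out of trifluoromethoxy brings no number back into range. Among the compounds shown, only compound 1 with its tert-butyl group gives a number at this position, while the others all stop at the same limit: the limit of > 100000 nM in this assay, at which 3 of the 4 values shown sit.

The compounds shown leave open whether any group other than tert-butyl can give a number at this place, for instance an isopropyl group, a longer alkyl chain or an amine. They also leave open how far beyond the limit compound 2, compound 3 and compound 4 truly lie, and so whether these three differ from one another at all.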